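From compound 2 to compound 3: a 4-chlorobenzyl step

This account rests on a few compounds, and the source may have more. Where it says the series, first, only, none or still open, it means among the compounds named here.

In a functional assay on PC-3 cells (Homo sapiens) for cytotoxicity, read by WST assay, with a stated time of 48 h (on this read-out lower numbers stand for stronger inhibition and higher numbers for weaker inhibition), compound 2 (`N#C/C(=C\c1c[nH]c2ccccc12)C(=O)c1c[nH]c2ccccc12`) gives > 50000 nM as a limit of the assay and not a number. Compound 2 therefore stands at the limit of > 50000 nM in this assay, at which 2 of the 2 values shown sit, and has no exact reading yet.

Compound 3 (`N#C/C(=C\c1cn(Cc2ccc(Cl)cc2)c2ccccc12)C(=O)c1c[nH]c2ccccc12`) has not been measured. It carries 4-chlorobenzyl in place of hydrogen on an aromatic nitrogen of compound 2.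

Within the data shown here, no measured step shows directly what this change does. Compound 1 (`N#C/C(=C\c1cn(Cc2ccc(Cl)cc2)c2ccccc12)C(=O)c1c[nH]c2cc(F)ccc12`) also carries a 4-chlorobenzyl group and gives > 50000 nM as a limit too, so no clear gain in this assay is expected for compound 3. The step is estimated as a number no higher from compound 2 to compound 3 (the limit leaves the size open) and is expected to stay within the usual scatter, in neither direction. For compound 3 the estimate is 50000 nM with an expected range from 15000 nM to 100000 nM and a reading at the limit is the likeliest outcome.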

Compound 3, half-maximal inhibitory concentration: > 50000 nM
Compound 3 was reported as a limit; the forecaster's own chance of this, stated with the estimate: 75%; the middle value sits exactly at the limit.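

In this assay, the steps linking compound 3 to compound 2 and to compound 1 cannot be read, because all three compounds are reported only as a limit of the assay and not a number: the limit of > 50000 nM in this assay, at which 3 of the 3 values shown sit.

The compounds shown leave open how strongly any of the three acts on these cells, and whether 4-chlorobenzyl or fluoro changes that at all.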